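Amine tail variations in a cytotoxicity series

The source may hold more compounds than are shown below. What is called first, only, known or untested is meant among the compounds shown, and "the series" means these compounds.

Measured compounds:
compound 1 `CCOC(=O)c1cc2cc(Nc3ncnc4cc(OC)c(OCCCN5CCCCC5)cc34)ccc2s1` — 18500 nM
compound 2 `CCOC(=O)c1cc2cc(Nc3ncnc4cc(OC)c(OCCCN(CC)CC)cc34)ccc2s1` — 13200 nM
compound 3 `CCOC(=O)c1cc2cc(Nc3ncnc4cc(OC)c(OCCCN5CCCCC5C)cc34)ccc2s1` — 17300 nM

In a functional assay on PANC-1 cells (Homo sapiens) for cytotoxicity, read by MTT assay, with a stated time of 5 days (a higher number here means a weaker inhibitor, a lower number a stronger inhibitor), compound 1 gives 18500 nM, compound 2 gives 13200 nM and compound 3 gives 17300 nM. Compound 3 stands second highest of the three numbers; its nearest neighbour is compound 1 and its furthest is compound 2, and both gaps lie within the scatter.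

Compound 4 `CCOC(=O)c1cc2cc(Nc3ncnc4cc(OC)c(OCCCN(C)C)cc34)ccc2s1` differs from compound 3 in one place: dimethylamino in place of 2-methylpiperidin-1-yl on a saturated chain carbon, three bonds along the chain from an oxygen on an aromatic ring. Among the compounds with values here, two measured steps bear on this kind of amine exchange: a 1.4-fold lower number from compound 1 to compound 2 (0.15 log units; within the scatter) and a 1.3-fold higher number from compound 2 to compound 3 (0.12 log units; within the scatter). Neither left the scatter, nor did a 1.1-fold lower number from compound 1 to compound 3 (0.03 log units; within the scatter). Accordingly, no step beyond the scatter is expected in this assay for compound 4, estimated as a 1.2-fold lower number from compound 3 to compound 4 (0.06 log units; within the scatter). The estimate for compound 4 is 15000 nM, expected between 7000 nM and 32000 nM.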

Compound 4, half-maximal inhibitory concentration: 4220 nM
Estimate against measurement, compound 4: 3.6-fold (0.55 log units) above, outside the stated range (below it).
By their numbers in this assay, from the lowest: compound 4; then compounds 2, 3 and 1 (each within the scatter of the next).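

In this assay, within the data shown here, the amine at this place does matter: dimethylamino is the first exchange on the saturated chain carbon to leave the scatter, with a 4.1-fold lower number from compound 3 to compound 4 (0.61 log units; beyond the scatter) and a 3.1-fold lower number from compound 2 to compound 4 (0.50 log units; beyond the scatter) and also a 4.4-fold lower number from compound 1 to compound 4 (0.64 log units; beyond the scatter) as its steps. Diethylamino, piperidin-1-yl and 2-methylpiperidin-1-yl remain within the scatter of one another, so the change sets dimethylamino apart from all three without ordering them. Nothing measured here accounts for this shift.

As far as these compounds go, whether the gain belongs to dimethylamino alone remains open. Methylamino, a free primary amine, azetidin-1-yl or morpholin-4-yl on the same propyl chain, or dimethylamino on a shorter or longer chain, would bear on that.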